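Shrinking the Ring: From Compound 3 to Compound 4

The compounds below may be only part of what the source reports. "The series", "measured", "known", "first", "only" and "open" are said of these compounds alone.

All numbers come from a functional assay on HEK293 cells for agonist activity at G-protein coupled receptor 39 (Homo sapiens), read by inositol phosphate accumulation; on this read-out lower numbers stand for an effect already at smaller amounts and higher numbers for an effect only at larger amounts of compound:
compound 1 `COCCNc1nc(NCC2CC2)cc(-c2ccccn2)n1` gives 2200 nM
compound 2 `c1ccc(-c2cc(NCC3CC3)ncn2)nc1` gives 22000 nM
compound 3 `CNc1nc(NCC2CCCCC2)cc(-c2ccccn2)n1` gives 11 nM

Among these three, compound 3 stands at the lowest number, compound 1 comes next, and compound 2 sits highest; each of these gaps lies beyond the usual scatter. Compound 4 `CNc1nc(NCC2CC2)cc(-c2ccccn2)n1` is a new member of the set. Its change against compound 3 is cyclopropyl in place of cyclohexyl on a saturated chain carbon bound to a nitrogen on an aromatic ring.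

Among the compounds with values here, no measured pair isolates this exact change. Within the data shown here, the only single-place step known is a 10-fold higher number from compound 1 to compound 2 (1.00 log units; beyond the scatter), and it concerns a different position on the shared core, so it says little about swapping one ring for another on the saturated chain carbon. Compound 1 does carry the same cyclopropylmethyl group as compound 4, and in this assay compound 1 gives 2200 nM; yet compound 1 and compound 3 also differ at a second place, so the wide gap between them cannot be assigned to the ring alone.

Since compound 1 with the smaller ring sits far above compound 3, and because compound 3 gives 11 nM, a rise is expected, roughly a 27-fold higher number from compound 3 to compound 4 (1.44 log units; beyond the scatter). Compound 4 is estimated at 300 nM, with a likely range of 40 nM to 2500 nM.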

Compound 4, half-maximal effective concentration: 164 nM
For compound 4 the middle estimate is 1.8-fold (0.26 log units) above the measured one; the range from low to high includes it.
By their numbers in this assay, from the lowest: compound 3; then compound 4; then compound 1; then compound 2.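

In this assay, cyclopropyl in place of cyclohexyl gives a 15-fold higher number from compound 3 to compound 4 (1.17 log units; beyond the scatter) as a change in one place only, so the choice of ring on this saturated chain carbon moves the number beyond the scatter without any second difference to share the credit. With the cyclopropylmethyl group held fixed, methylamino in place of hydrogen on an aromatic carbon brings a 130-fold lower number from compound 2 to compound 4 (2.13 log units; beyond the scatter) and shows that the other position matters even more in this comparison. Shortening the group at that same position, with hydrogen in place of methoxymethyl, brings a 13-fold lower number from compound 1 to compound 4 (1.13 log units; beyond the scatter) and places the methylamino compound below both its hydrogen and its (2-methoxyethyl)amino partners.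

The compounds shown leave open where a cyclopentyl ring or an open chain such as n-butyl would fall at the ring position, and whether the ring step would keep its size with (2-methoxyethyl)amino in place of methylamino. Nothing given here bears on why the numbers move as they do.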